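Chloro on the diphenylmethyl group: compound 1 to compound 3

A few compounds are considered here, and "the series" means these few. Any claim that something is new, unique, unknown or untested is made for them only; others in the source may bear on it.

Compound 1, `COC(=O)CC/C(C)=C/Cc1c(OC)c(C)c2c(c1OCC#CCN1CCN(C(c3ccccc3)c3ccccc3)CC1)C(=O)OC2`, is one of two members of this series measured so far, and in a functional assay on HT-29 cells (Homo sapiens) for inhibition, read by sulforhodamine B assay (on this read-out lower numbers stand for stronger inhibition and higher numbers for weaker inhibition), compound 1 gives > 50000 nM. That figure is a limit of the assay, not a number. Compound 2, `COC(=O)CC/C(C)=C/Cc1c(OC)c(C)c2c(c1OCC#CCN1CCCc3ccccc31)C(=O)OC2`, carries a different amine on the alkyne chain; in this assay compound 2 gives > 50000 nM, again a limit of the assay rather than a measured concentration. What the two measured compounds share is the limit of > 50000 nM in this assay, at which 2 of the 2 values shown sit. Compound 1 therefore stands nowhere distinguishable from compound 2: both lie outside the range the assay resolves, and no ordering between them can be read.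

Compound 3, `COC(=O)CC/C(C)=C/Cc1c(OC)c(C)c2c(c1OCC#CCN1CCN(C(c3ccccc3)c3ccc(Cl)cc3)CC1)C(=O)OC2`, is the untested analogue of compound 1. The change is chloro in place of hydrogen on an aromatic carbon. Among the measured compounds shown here, no pair of measured compounds differing in one place exists, so no step size is known. Both measured points are limits, and the change enters only one heavy atom; the expectation is that the value for compound 3 is once more a limit. The step that the limit leaves unreadable from compound 1 to compound 3 is expected to be none beyond the scatter. Compound 3 is expected to give about 60000 nM, between 20000 nM and 200000 nM.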

Compound 3, half-maximal inhibitory concentration: > 50000 nM
Compound 3 was reported as a limit (the forecaster's own chance of this, stated with the estimate: 85%); the middle value is on the limit's open side.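

No step can be read from compound 1 to compound 3, since both values are limits of the assay and not numbers: the limit of > 50000 nM in this assay, at which 3 of the 3 values shown sit.

The compounds shown leave open whether any member of the series gives a measurable value in this assay, and so what size of step, if any, goes with phenyl to 4-chlorophenyl.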